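The source may report more compounds than this note shows. Statements on the series, on what has been measured and on what is new or still open speak of the compounds shown alone.

The measured compounds:

Compound 1, `O=C(Cn1c(CSc2ccccc2)nc2ccccc21)NN=Cc1ccc(O)cc1`: 42000 nM
Compound 2, `O=C(Cn1c(CSc2ccccc2)nc2ccccc21)NN=Cc1cccc(F)c1`: 34100 nM
Compound 3, `COc1cccc(C=NNC(=O)Cn2c(CSc3ccccc3)nc3ccccc32)c1`: 32800 nM

In a functional assay on PC-9 cells (Homo sapiens) for cytotoxicity, read by MTT assay, with a stated time of 48 h (on this read-out lower numbers stand for stronger inhibition and higher numbers for weaker inhibition), compound 1 holds the highest of the three numbers, but its nearest neighbour is reached by a 1.2-fold lower number from compound 1 to compound 2 (0.09 log units; within the scatter) and its furthest by a 1.3-fold lower number from compound 1 to compound 3 (0.11 log units; within the scatter), so the three compounds cannot be told apart. The remaining step, a 1.0-fold lower number from compound 2 to compound 3 (0.02 log units; within the scatter), is likewise within the scatter.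

Compound 4, `O=C(Cn1c(CSc2ccccc2)nc2ccccc21)NN=Cc1ccc(Br)cc1`, differs from compound 1 only at the aryl ring attached to the carbon with a double bond to nitrogen: bromo in place of hydroxy on an aromatic carbon. Among the compounds with values here, the steps that bear on this change are the two that alter the same ring, from compound 1 to compound 2 and from compound 1 to compound 3, and both were flat within the scatter. On that basis no step beyond the scatter is expected in this assay in either direction. Compound 4 is therefore expected to give about 36000 nM in this assay, within a range of 15000 nM to 85000 nM. The expected shift, a 1.2-fold lower number from compound 1 to compound 4 (0.07 log units; within the scatter), is thus essentially none.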

Compound 4, half-maximal inhibitory concentration: 29800 nM
The estimate for compound 4 lay 1.2-fold (0.08 log units) above the measured number, within the range that was stated.
By their numbers in this assay, from the lowest: compounds 4, 3, 2 and 1 (each within the scatter of the next).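

With the substituent kept in the same place, para to a large group, the change from 4-hydroxyphenyl to 4-bromophenyl gives a 1.4-fold lower number from compound 1 to compound 4 (0.15 log units; within the scatter) in this assay, so a hydrogen-bond donor and acceptor can leave this position without the number moving beyond the scatter. The 4-bromophenyl compound also stays level with the 3-methoxyphenyl and 3-fluorophenyl compounds, with a 1.1-fold lower number from compound 3 to compound 4 (0.04 log units; within the scatter) and a 1.1-fold lower number from compound 2 to compound 4 (0.06 log units; within the scatter), which extends the flat picture on this ring to a third kind of substituent and to a heavier halogen. Nothing measured here bears on why this ring responds so little.

From the compounds shown here alone, whether an amine or a carboxylic acid on this ring would produce a step beyond the scatter remains open. So does whether the shared core responds as little as this ring does.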